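Replacing the fluoropyridine of compound 2 with a methylpyrazole

This account rests on a few compounds, and the source may have more. Where it says the series, first, only, none or still open, it means among the compounds named here.

In a functional assay on CWR22R cells (Homo sapiens) for antiproliferative activity, read by CCK-8 assay, with a stated time of 6 days (on this read-out higher numbers stand for weaker inhibition and lower numbers for stronger inhibition), compound 1 `CCN(c1ccc(C#N)c(Cl)c1)c1cc(-c2ccccc2)ccc1C` reads > 30000 nM, which is a limit of the assay and not a number. Among the compounds with values here, compound 2 `CCN(c1ccc(C#N)c(Cl)c1)c1cc(-c2ccc(F)nc2)ccc1C` gives 16500 nM, the only actual number so far. The next analogue is compound 3 `CCN(c1ccc(C#N)c(Cl)c1)c1cc(-c2c[nH]nc2C)ccc1C`, with 3-methyl-1H-pyrazol-4-yl in place of 6-fluoropyridin-3-yl on an aromatic carbon. Within the data shown here, one measured step bears on this change, at the same substituent: an at least 1.8-fold lower number from compound 1 to compound 2 (0.25 log units; that floor lies within the scatter). Its size is only a floor, set by the limit of > 30000 nM in this assay, at which 1 of the 2 values shown sits, so it gives direction weakly and size hardly at all. A further move toward stronger inhibition in this assay is therefore expected, with wide uncertainty. The estimated change is a 2.8-fold lower number from compound 2 to compound 3 (0.44 log units; beyond the scatter). For compound 3, the estimate is 6000 nM, with an expected range of 1000 nM to 30000 nM.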

Compound 3, half-maximal inhibitory concentration: 5380 nM
The estimate for compound 3 lay 1.1-fold (0.05 log units) above the measured number; low and high end bracket the measured number.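

Within the data shown here, at the aromatic carbon para to a methyl group, in this assay, the change from 6-fluoropyridin-3-yl to 3-methyl-1H-pyrazol-4-yl gives a 3.1-fold lower number from compound 2 to compound 3 (0.49 log units; beyond the scatter) as the first step between two actual numbers. Against phenyl, the same group gives an at least 5.5-fold lower number from compound 1 to compound 3 (0.74 log units; beyond the scatter) and so clears the scatter, which the earlier floor for the fluoropyridine did not. That size remains only a floor, because compound 1 sits at a limit of the assay and not at a number: (the limit of > 30000 nM in this assay, at which 1 of the 3 values shown sits).

The step swaps a six-membered ring for a five-membered one, adds a hydrogen-bond donor and brings in a methyl group, and the compounds shown do not separate these differences. Open too, going by these compounds, is how a pyrazole without the methyl group, or one with a methyl on its ring nitrogen, would read here.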